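A few compounds are considered here, and "the series" means these few. Any claim that something is new, unique, unknown or untested is made for them only; others in the source may bear on it.

Measured compounds:
- compound 1 `NC1=NC2(CCOCC2)N(OCCCOc2cccc(Cl)c2)C(N)=N1`, in an assay on isolated protein for inhibition of Dihydrofolate reductase (Homo sapiens), read by spectrophotometry, using NADPH, with stated times of 5 s and 6 min (a lower number here means a stronger inhibitor, a higher number a weaker inhibitor), compound 1 gives "not determined" (no result reported)
- compound 2 `NC1=NC2(CCOCC2)N(OCCCOc2ccc(F)cc2)C(N)=N1`, in this assay compound 2 gives 46.6 nM
- compound 3 `NC1=NC2(CCSCC2)N(OCCCOc2cccc(Cl)c2Cl)C(N)=N1`, in this assay compound 3 gives "not determined" (no result reported)

For the measured compounds named here, of the three compounds with a result sheet, only compound 2 carries a number in this assay; compound 1 and compound 3 have no result reported there, so nothing can be said about how they compare with compound 2, and no step between measured compounds is available.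

The next compound, compound 4 `NC1=NC2(CCOCC2)N(OCCCOc2ccc(Cl)cc2)C(N)=N1`, differs from compound 2 in one place: chloro in place of fluoro on an aromatic carbon. The shared core and the linker to the aromatic ring are unchanged.

Going by the values given here, with no measured step to lean on, the expectation for this assay rests on the change itself: one halogen for another on an aromatic carbon, para to a large group. A step within the usual scatter is expected, leaning if anything toward a slightly stronger inhibitor, but not beyond the scatter with any confidence. The step from compound 2 to compound 4 is therefore estimated at a 1.3-fold lower number from compound 2 to compound 4 (0.12 log units; within the scatter).

Compound 4 is expected to give about 35 nM in this assay, within a range of 12 nM to 110 nM.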

Compound 4, half-maximal inhibitory concentration: 33.6 nM
Compound 4: middle estimate off by 1.0-fold (0.02 log units), on the high side, within the range that was stated.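

For the compounds shown here, this is the first measured step, and it shows that at this position, on an aromatic carbon para to a large group, chloro can stand in place of fluoro without a step that can be separated from repeat-measurement noise: in this assay the exchange reads a 1.4-fold lower number from compound 2 to compound 4 (0.14 log units; within the scatter). The 4-fluorophenyl and 4-chlorophenyl ends therefore count as equivalent in this read-out, with the shared core and the linker held constant, and the value of this position for further comparison is that the two halogens give one common reference level. Nothing measured here speaks to why the two halogens read alike.

From the compounds shown here alone, what a group of another kind would do at this position, such as an amine, a carboxylic acid or a longer chain, stays open, since two halogens alone mark out only a narrow part of what the position might accept. Compound 1 differs from compound 4 only in where the chloro sits on the ring, but in this assay compound 1 gives "not determined" (no result reported), so the effect of that placement cannot be read.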